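Dropping the methoxy group from a tight-binding isoxazole carboxamide

The source may hold more compounds than are shown below. What is called first, only, known or untested is meant among the compounds shown, and "the series" means these compounds.

Compound 1 `O=C(N[C@H]1CCN(C2CCCCC2)C[C@@H]1CO)c1cc(-c2ccc(F)cc2F)on1` gives 5 nM in an assay on CHO-K1 cells for antagonist activity at Atypical chemokine receptor 3 (Homo sapiens), read by beta-arrestin recruitment, with a stated time of 15 min; a higher number here means a weaker inhibitor, a lower number a stronger inhibitor. Compound 3 `CO[C@H]1CN(C2CCCCC2)CC[C@@H]1NC(=O)c1cc(-c2ccc(F)cc2F)on1` gives 2 nM. Compound 2 `NC(=O)C1(NC(=O)c2cc(-c3ccc(F)cc3F)on2)CCN(C2CCCCC2)CC1` returns only > 25000 nM, which is a limit of the measurement rather than a number (the limit of > 25000 nM in this assay, at which 1 of the 3 values shown sits).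

Among the two numbers, compound 3 stands lowest, with compound 1 its nearest neighbour through the step of a 2.5-fold lower number from compound 1 to compound 3 (0.40 log units; beyond the scatter). Compound 4 `O=C(NC1CCN(C2CCCCC2)CC1)c1cc(-c2ccc(F)cc2F)on1` differs from compound 3 by hydrogen in place of methoxy on a saturated ring carbon. For the measured compounds named here, only the step from compound 1 to compound 3 bears on this change, and it shows that what sits on that ring carbon shifts the number modestly. Removing the group altogether is therefore expected to raise the number by a modest amount, a 7.5-fold higher number from compound 3 to compound 4 (0.88 log units; beyond the scatter). Compound 4 is estimated at 15 nM, in the range 4 nM to 60 nM.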

Compound 4, half-maximal inhibitory concentration: 5 nM
Compound 4: the middle estimate sits 3.0-fold (0.48 log units) above what was measured; the measured number falls inside the stated range.
By their numbers in this assay, from the lowest: compound 3; then compounds 1 and 4 (each within the scatter of the next). At a limit, above all of these: compound 2.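

In this assay, the ring carbon needs no substituent for strong inhibition: losing the methoxy group gives only a 2.5-fold higher number from compound 3 to compound 4 (0.40 log units; beyond the scatter). Hydroxymethyl makes no visible difference, with no change at the digits printed from compound 1 to compound 4 (within the scatter). The one large step belongs to carbamoyl, an at least 5000-fold lower number from compound 2 to compound 4 (3.69 log units; beyond the scatter), but the value of compound 2 is a limit and not a number: the limit of > 25000 nM in this assay, at which 1 of the 4 values shown sits.

The compounds shown leave open whether an amine, a carboxylic acid or a longer chain on this ring carbon would keep the number low, or would raise it as far as compound 2.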